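The source may hold more compounds than are shown below. What is called first, only, known or untested is meant among the compounds shown, and "the series" means these compounds.

Compound 1 `COc1ccc(/C=N/NC(=S)NC(C)(C)[C@H]2CC=C(C)CC2)cc1`: 31200 nM. Compound 2 `CC1=CC[C@H](C(C)(C)NC(=S)N/N=C/c2ccc(N(C)C)cc2)CC1`: 26800 nM. Compound 3 `COc1cc(/C=N/NC(=S)NC(C)(C)[C@H]2CC=C(C)CC2)ccc1O`: 14800 nM.

In a functional assay on MCF7 cells (Homo sapiens) for inhibition, read by sulforhodamine B assay, with a stated time of 48 h (a lower number here means a stronger inhibitor of growth, a higher number a weaker inhibitor of growth), compound 1 gives the highest of the three numbers; compound 2 lies within the scatter of it, while compound 3 sits beyond the scatter below it. Compound 4 `CC1=CC[C@H](C(C)(C)NC(=S)N/N=C/c2ccco2)CC1` differs from compound 1 by furan-2-yl in place of 4-methoxyphenyl on a carbon with a double bond to nitrogen. Within the data shown here, only one measured step touches the same part of the molecule, a 1.2-fold lower number from compound 1 to compound 2 (0.07 log units; within the scatter), and it exchanges a substituent on that ring rather than the ring itself; no measured step replaces the whole aromatic ring. The step from compound 1 to compound 4 is therefore expected to remain small, with no clear direction. For compound 4 the estimated value is 25000 nM, between 8000 nM and 80000 nM, which corresponds to an expected step of a 1.2-fold lower number from compound 1 to compound 4 (0.10 log units; within the scatter).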

Compound 4, concentration for 50% growth inhibition: 9300 nM
Estimate against measurement, compound 4: 2.7-fold (0.43 log units) above, within the range that was stated.
By their numbers in this assay, from the lowest: compounds 4, 3, 2 and 1 (each within the scatter of the next, the first and the last beyond it).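

In this assay, exchanging the whole aromatic ring shifts the number beyond the scatter, a 3.4-fold lower number from compound 1 to compound 4 (0.53 log units; beyond the scatter), whereas exchanging a substituent on that ring stayed within it, a 1.2-fold lower number from compound 1 to compound 2 (0.07 log units; within the scatter). The place on the carbon with a double bond to nitrogen therefore accepts furan-2-yl in place of 4-methoxyphenyl without loss of growth inhibition. Nothing measured here explains this shift.

A thiophene or pyridine ring at this place could separate the contribution of ring size from that of the ring oxygen. As far as these compounds go, whether a saturated ring such as tetrahydrofuran would keep the lower number also remains open.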